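A Dimethylphenyl Swap on Compound 1

This account rests on a few compounds, and the source may have more. Where it says the series, first, only, none or still open, it means among the compounds named here.

Values measured so far in a toxicity assay on HUVEC cells (Homo sapiens) for inhibition (a higher number here means a weaker inhibitor of growth, a lower number a stronger inhibitor of growth), are these

- compound 1 `Cc1nc(-c2ccccc2)c(C(=O)N2CCN(c3cccc(Cl)c3)CC2)o1` gives 0.463 ug/mL
- compound 2 `Cc1nc(-c2ccccc2)c(C(=O)N2CCN(c3cccc(C)c3C)CC2)o1` gives 0.38 ug/mL
- compound 3 `Cc1nc(-c2ccccc2F)c(C(=O)N2CCN(c3cc(Cl)cc(Cl)c3)CC2)o1` gives 0.177 ug/mL

Compound 1 and compound 2 lie within the scatter of each other, while compound 3 shows a lower number than compound 1 by more than the scatter. Compound 4 `Cc1cc(C)cc(N2CCN(C(=O)c3oc(C)nc3-c3ccccc3)CC2)c1` has yet to be measured in this assay and shares the core of compound 1. The change is 3,5-dimethylphenyl in place of 3-chlorophenyl on an amine nitrogen in a ring and consists of 3,5-dimethylphenyl in place of 3-chlorophenyl on an amine nitrogen in a ring.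

For the measured compounds named here, one measured step bears directly on this place. With 2,3-dimethylphenyl in place of 3-chlorophenyl on the same nitrogen, the data show a 1.2-fold lower number from compound 1 to compound 2 (0.09 log units; within the scatter) and this step is small. Going by the values given here, compound 2 is the only measured compound that carries two methyl groups on this phenyl ring, and it rests on a single comparison. On that evidence, no step beyond the scatter is expected for the new pair. The expected step is a 1.3-fold lower number from compound 1 to compound 4 (0.11 log units; within the scatter) and it may run either way within the range given here. For compound 4 the estimated value is 0.36 ug/mL in this assay, with an expected range from 0.16 ug/mL to 0.8 ug/mL.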

Compound 4, concentration for 50% growth inhibition: 0.356 ug/mL
For compound 4 the middle estimate is 1.0-fold (0.00 log units) above the measured one; low and high end bracket the measured number.
By their numbers in this assay, from the lowest: compounds 3, 4, 2 and 1 (each within the scatter of the next, the first and the last beyond it).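

In this assay, for the compounds shown here, the 3,5-dimethylphenyl group gives a 1.3-fold lower number from compound 1 to compound 4 (0.11 log units; within the scatter), so compound 2 is no longer the only compound with two methyl groups on this phenyl ring that stays within the scatter of compound 1. The second step, a 1.1-fold lower number from compound 2 to compound 4 (0.03 log units; within the scatter), adds that the two dimethylphenyl groups cannot be told apart in this assay, and the arrangement of the methyl groups on the ring makes no measurable difference across this pair. Nothing available explains why these groups and the 3-chlorophenyl group sit so close together on the amine nitrogen of the shared core.

The compounds shown carry only chlorine and methyl groups on this phenyl ring, so it remains open whether an amine, a carboxylic acid or a longer chain there would also stay within the scatter of compound 1. Compound 3 differs from compound 1 in more than one place, which leaves open whether its lower number belongs to the groups on the ring at the amine nitrogen or to the fluorine on the other phenyl ring.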